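A few compounds are considered here, and "the series" means these few. Any claim that something is new, unique, unknown or untested is made for them only; others in the source may bear on it.

Measured so far in a functional assay on A549 cells (Homo sapiens) for cytotoxicity, read by MTT assay, with a stated time of 72 h; on this read-out lower numbers stand for stronger inhibition and higher numbers for weaker inhibition:
- compound 1 `O=S(=O)(c1ccccc1)c1nc2ccccc2nc1N1CCCC(O)C1`: 310 nM
- compound 2 `COc1ccc(S(=O)(=O)c2nc3ccccc3nc2N2CCCC(O)C2)cc1`: 2180 nM

Compound 2, at 2180 nM, has the higher of the two numbers in this assay, making it the weaker of the pair. Compound 3 `O=S(=O)(c1ccc(Br)cc1)c1nc2ccccc2nc1N1CCCC(O)C1` keeps the same shared core but carries bromo in place of methoxy on an aromatic carbon, para to a large group (bromo in place of methoxy on an aromatic carbon).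

For the measured compounds named here, only one measured step bears on this change: a 7.0-fold higher number from compound 1 to compound 2 (0.85 log units; beyond the scatter), a modest rise that came with methoxy in place of hydrogen at that same spot. Compound 3 also lacks the methoxy, so a move towards lower numbers is expected. Going by the values given here, no measured compound carries bromo, however, so the move may be smaller than that step, and it remains uncertain. The expected change is a 2.7-fold lower number from compound 2 to compound 3 (0.44 log units; beyond the scatter). For compound 3 the estimated value is 800 nM, with an expected range of 220 nM to 2800 nM.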

Compound 3, half-maximal inhibitory concentration: 2100 nM
Beside the measured number, compound 3's estimate is 2.6-fold (0.42 log units) below it; measured number inside the range.
By their numbers in this assay, from the lowest: compound 1; then compounds 3 and 2 (each within the scatter of the next).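

In this assay, bromo in place of methoxy gives (a 1.0-fold lower number from compound 2 to compound 3 (0.02 log units; within the scatter)), so the two groups cannot be told apart at this position. Bromo in place of hydrogen gives (a 6.8-fold higher number from compound 1 to compound 3 (0.83 log units; beyond the scatter)), a step close in size to the one with methoxy (a 7.0-fold higher number from compound 1 to compound 2 (0.85 log units; beyond the scatter)), so the higher number is not peculiar to methoxy: in these three compounds, both groups at this spot read higher than hydrogen. Nothing available explains why two such different groups land together.

The compounds shown carry only hydrogen, methoxy or bromo here, so it stays open whether fluoro, an amine or a carboxylic acid at this spot would read like compound 1 or like the other two. On these data alone, whether the pattern holds with other changes on the shared core also stays open.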